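This account rests on a few compounds, and the source may have more. Where it says the series, first, only, none or still open, it means among the compounds named here.

Measured in a functional assay on MC-38 cells (Mus musculus) for antiproliferative activity, read by CCK-8 assay, with a stated time of 48 h; on this read-out lower numbers stand for stronger inhibition and higher numbers for weaker inhibition:

- Compound 1 (`COc1ccc(/C=C\c2cc(OC)c(OC)c(OC)c2)cc1OCc1ccc(C=O)cc1`) : 900 nM
- Compound 2 (`COc1ccc(/C=C\c2cc(OC)c(OC)c(OC)c2)cc1OCc1ccc(CN2CCCC[C@H]2C(=O)O)cc1`) : > 10000 nM
- Compound 3 (`COc1ccc(/C=C\c2cc(OC)c(OC)c(OC)c2)cc1OCc1ccc(CO)cc1`) : 5700 nM

The value of compound 2 is a limit and not a number: > 10000 nM. Of the two exact numbers in this assay, compound 3 has the higher, 5700 nM. Compound 1 lies nearest, with a 6.3-fold higher number from compound 1 to compound 3 (0.80 log units; beyond the scatter).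

Compound 4 (`COc1ccc(/C=C\c2cc(OC)c(OC)c(OC)c2)cc1OCc1ccc(CN2CC[C@@H](C(=O)O)C2)cc1`) has not yet been measured. It differs from compound 3 by 3-carboxypyrrolidin-1-yl in place of hydroxy on a saturated chain carbon bound to an aromatic carbon.

Within the data shown here, the closest precedent is compound 2, which also carries a carboxylated saturated ring on that carbon. The large rise seen as an at least 11-fold higher number from compound 1 to compound 2 (1.04 log units; beyond the scatter) sets it apart from compound 1, while an at least 1.7-fold lower number from compound 2 to compound 3 (0.24 log units; that floor lies within the scatter) shows a floor that lies within the scatter. A small rise in the number is therefore expected in this assay, and the result may arrive only as a limit. The expected change is a 1.9-fold higher number from compound 3 to compound 4 (0.29 log units; within the scatter). For compound 4 the estimated value is 11000 nM. The expected range for compound 4 runs from 4000 nM to 30000 nM.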

Compound 4, half-maximal inhibitory concentration: 6300 nM
Compound 4: the middle estimate sits 1.7-fold (0.24 log units) above what was measured; measured number inside the range.
By their numbers in this assay, from the lowest: compound 1; then compounds 3 and 4 (each within the scatter of the next). At a limit, above all of these: compound 2.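

In this assay, 3-carboxypyrrolidin-1-yl on a saturated chain carbon bound to an aromatic carbon gives an exact number, and the step from hydroxy, a 1.1-fold higher number from compound 3 to compound 4 (0.04 log units; within the scatter), shows that this larger ring-bearing group and hydroxy cannot be told apart here. Formyl remains apart from this group, with a 7.0-fold higher number from compound 1 to compound 4 (0.85 log units; beyond the scatter), so both compound 3 and compound 4 lie on the weaker side of compound 1. The step of an at least 1.5-fold lower number from compound 2 to compound 4 (0.20 log units; that floor lies within the scatter) does not order the two carboxylated rings, because compound 2 stands at a limit: the limit of > 10000 nM in this assay, at which 1 of the 4 values shown sits.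

Going by these compounds, it remains open whether a plain pyrrolidin-1-yl without the carboxylic acid, or a carboxylic acid on a longer chain, would read closer to compound 1 or to compound 4. The mirror-image form of 3-carboxypyrrolidin-1-yl is also left open.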